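The source may report more compounds than this note shows. Statements on the series, on what has been measured and on what is new or still open speak of the compounds shown alone.

Compound 3 `CC(=O)NN1C(=O)C(Cc2ccccc2)=NN2C1=NN(C(C)=O)C2(C)c1ccc(Cl)cc1` gives 5.69 nM in an assay on microsomes from liver for inhibition of cytochrome P450 1A1 (Rattus norvegicus), read by fluorescence, with a stated time of 10 min (on this read-out lower numbers stand for stronger inhibition and higher numbers for weaker inhibition), the lowest of the three numbers recorded there. Compound 1 `CC(=O)NN1C(=O)C(Cc2ccccc2)=NN2C1=NN(C(C)=O)C2(C)c1ccc(C)cc1` gives 6.62 nM in this assay, and the step of a 1.2-fold lower number from compound 1 to compound 3 (0.07 log units; within the scatter) separates the two. Compound 2 `CC(=O)N1N=C2N(N=C(Cc3ccccc3)C(=O)N2N(C(C)=O)C(C)=O)C1c1ccccc1` differs from compound 3 in several places. In this assay compound 2 gives 24.2 nM, a number beyond the scatter from that of compound 3. Compound 4 `CC(=O)NN1C(=O)C(Cc2ccccc2)=NN2C1=NN(C(C)=O)C2(C)c1ccccc1` has not been measured; it differs from compound 3 by hydrogen in place of chloro on an aromatic carbon. Among the measured compounds shown here, the only step that bears on this change is the one from compound 1 to compound 3, which stayed within the scatter, so no step beyond the scatter is expected for a 1.4-fold higher number from compound 3 to compound 4 (0.15 log units; within the scatter). Compound 4 is therefore estimated at 8 nM in this assay, within a range of 4 nM to 16 nM.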

Compound 4, half-maximal inhibitory concentration: 13.2 nM
The estimate for compound 4 lay 1.7-fold (0.22 log units) below the measured number, and the stated range covers the measured number.
By their numbers in this assay, from the lowest: compounds 3, 1, 4 and 2 (each within the scatter of the next, the first and the last beyond it).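

Hydrogen in place of chloro, on the aromatic carbon para to a large group, gives a 2.3-fold higher number from compound 3 to compound 4 (0.37 log units; beyond the scatter), the first step at this position to pass the scatter, though only modestly. Hydrogen in place of methyl gives a 2.0-fold higher number from compound 1 to compound 4 (0.30 log units; within the scatter), so the position responds to one of these replacements but not to the other. Nothing available explains that contrast. From the compounds shown here alone, only chloro, methyl and hydrogen appear at this position, so an amine, a methoxy group or a carboxylic acid there remains open.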